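The source may hold more compounds than are shown below. What is called first, only, known or untested is meant among the compounds shown, and "the series" means these compounds.

In a physicochemical assay for solubility, measured as thermodynamic solubility, at pH 7.4 (a lower number here means a less soluble compound, a higher number a more soluble compound), three compounds have been measured so far:

- compound 1 `CC(C)N1Cc2c(NC(c3ccccc3)c3ccccc3)nc(N3CCNCC3)nc2C1=O` gives 1000000 nM
- compound 2 `CC(=O)N1CCN(c2nc(NC(c3ccccc3)c3ccccc3)c3c(n2)C(=O)N(C(C)C)C3)CC1` gives < 1000 nM, which is a limit of the assay and not a number
- compound 3 `CC(C)N1Cc2c(NC(c3ccccc3)c3ccccc3)nc(N3CCN(CC(=O)N(C)C)CC3)nc2C1=O` gives 3500 nM

Of the two actual numbers, compound 3 has the lower one. The limit for compound 2 leaves its exact place open.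

The next compound is compound 4 `CC(C)N1Cc2c(NC(c3ccccc3)c3ccccc3)nc(N3CCN(C(=O)CN(C)C)CC3)nc2C1=O`, which has the same atoms as compound 3, joined differently. It carries ((dimethylamino)methyl)carbonyl in place of (dimethylcarbamoyl)methyl on an amine nitrogen in a ring.

Among the compounds with values here, three measured steps bear on this change, all at that same nitrogen. Two replace its hydrogen and are large: acetyl gives an at least 1000-fold lower number from compound 1 to compound 2 (3.00 log units; beyond the scatter), and (dimethylcarbamoyl)methyl gives a 290-fold lower number from compound 1 to compound 3 (2.46 log units; beyond the scatter). The third, from acetyl to (dimethylcarbamoyl)methyl, gives an at least 3.5-fold higher number from compound 2 to compound 3 (0.54 log units; beyond the scatter). Within the data shown here, no measured step makes the exact swap in compound 4, so any expectation here is loose.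

The ring nitrogen of compound 4 carries a carbonyl, as in compound 2, which points downward. Its dimethylamino nitrogen carries no carbonyl, like the ring nitrogen of compound 1 at 1000000 nM, which points upward. On balance, the expected change is a moderate rise, a 5.7-fold higher number from compound 3 to compound 4 (0.76 log units; beyond the scatter). Compound 4 is estimated at 20000 nM, with an expected range of 2500 nM to 200000 nM.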

Compound 4, solubility: 50000 nM
For compound 4 the middle estimate is 2.5-fold (0.40 log units) below the measured one; the range from low to high includes it.
By their numbers in this assay, from the lowest: compound 3; then compound 4; then compound 1. At a limit, below all of these: compound 2.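

In this assay, the same atoms joined differently on this ring nitrogen give a clear change: a 14-fold higher number from compound 3 to compound 4 (1.15 log units; beyond the scatter), so the order of carbonyl and dimethylamino along the group matters here, and the atom count alone does not settle the read-out. Dimethylamino on the saturated chain carbon bound to the carbonyl carbon also separates the two carbonyl-bearing groups, an at least 50-fold higher number from compound 2 to compound 4 (1.69 log units; beyond the scatter), yet replacing the hydrogen on this nitrogen with ((dimethylamino)methyl)carbonyl still leaves a large step, a 20-fold lower number from compound 1 to compound 4 (1.30 log units; beyond the scatter), so none of the three groups here reaches the number of the unsubstituted compound. The value for compound 2 is a limit of the assay and not a number, so its step gives only a minimum size: the limit of < 1000 nM in this assay, at which 1 of the 4 values shown sits.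

Going by these compounds, whether the gain depends on dimethylamino itself or would hold for another amine, such as pyrrolidine or morpholine, remains open. Also open, on these data alone, is how a longer chain carrying the dimethylamino group, or a carboxylic acid at the end of the chain, would behave at this nitrogen.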